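Working notes: the step from compound 3 to compound 4

The source may report more compounds than this note shows. Statements on the series, on what has been measured and on what is new or still open speak of the compounds shown alone.

compound 1 `Cc1ccc(NC(=O)CN2CCN(c3nnc(Cc4ccncc4)c4ccccc34)CC2)c(C)c1`: 1930 nM
compound 2 `O=C(CN1CCN(c2nnc(Cc3ccncc3)c3ccccc23)CC1)Nc1ccc(F)c(C(F)(F)F)c1`: 1110 nM
compound 3 `O=C(CN1CCN(c2nnc(Cc3ccncc3)c3ccccc23)CC1)Nc1c(F)cccc1F`: 28700 nM

All three values come from a functional assay on HT-29 cells (Homo sapiens) for cytotoxicity, read by MTT assay, with a stated time of 72 h; on this read-out lower numbers stand for stronger inhibition and higher numbers for weaker inhibition. Compound 3 has the highest number of the three, and its gaps to the other two lie beyond the scatter, so it is the weakest measured compound here.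

The next compound is compound 4 `Cc1cccc(Cl)c1NC(=O)CN1CCN(c2nnc(Cc3ccncc3)c3ccccc23)CC1`, which remains to be measured. The change is 2-chloro-6-methylphenyl in place of 2,6-difluorophenyl on an amide-type nitrogen, with the rest of the structure unchanged.

Going by the values given here, two measured steps bear on it, both large and both changes of this same group: a 15-fold higher number from compound 1 to compound 3 (1.17 log units; beyond the scatter) and a 26-fold higher number from compound 2 to compound 3 (1.41 log units; beyond the scatter). Replacing 2,6-difluorophenyl has so far only been seen in the reverse sense, and compound 1 and compound 2 lie within the scatter of each other, as a 1.7-fold lower number from compound 1 to compound 2 (0.24 log units; within the scatter) shows. Three compounds give a thin basis, and none carries 2-chloro-6-methylphenyl. The entering group keeps the 2 and 6 numbering of the group that leaves, so only part of those large steps is expected to be recovered.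

The expected change in this assay is a 4.1-fold lower number from compound 3 to compound 4 (0.61 log units; beyond the scatter), a moderate move towards a lower number. For compound 4 the estimate is 7000 nM, with an expected range from 1500 nM to 30000 nM.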

Compound 4, half-maximal inhibitory concentration: 22600 nM
Compound 4: the middle estimate sits 3.2-fold (0.51 log units) below what was measured, and the stated range covers the measured number.
By their numbers in this assay, from the lowest: compounds 2 and 1 (each within the scatter of the next); then compounds 4 and 3 (each within the scatter of the next).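

In this assay, 2-chloro-6-methylphenyl in place of 2,6-difluorophenyl on the amide-type nitrogen gives a 1.3-fold lower number from compound 3 to compound 4 (0.10 log units; within the scatter), so the two groups cannot be told apart here, even though both fluorine atoms leave and a chlorine and a further carbon enter. The large gap is thus not confined to 2,6-difluorophenyl: a 20-fold higher number from compound 2 to compound 4 (1.31 log units; beyond the scatter) and a 12-fold higher number from compound 1 to compound 4 (1.07 log units; beyond the scatter) show that both groups with 2 and 6 in their names stand well apart from 4-fluoro-3-(trifluoromethyl)phenyl and 2,4-dimethylphenyl, and none of the four compounds goes against this pattern. No evidence is available on what lies behind this pattern.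

As far as these compounds go, it remains open whether the pattern depends on having both the 2 and the 6 group, which a comparison of 2-chlorophenyl, 2-methylphenyl and unsubstituted phenyl with 2,6-dimethylphenyl on the same nitrogen could address. The compounds shown also leave open how the series responds when the aromatic ring on this nitrogen gives way to cyclohexyl, or when the ring carries an amine or a carboxylic acid.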